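This account rests on a few compounds, and the source may have more. Where it says the series, first, only, none or still open, it means among the compounds named here.

Measured so far in an ADME assay on microsomes from liver (Mus musculus) for metabolic stability, read by LC-MS, using NADPH, with stated times of 5 min and 30 min, tested at 1 uM; a lower number here means that less of the compound is left, a higher number that more of the compound is left:
compound 1 `O=C(O)c1ccc(-n2cc(C(=O)c3c(Cl)cccc3C(F)(F)F)c3cccnc32)c(F)c1` gives 87%
compound 2 `Cc1cccc(Cl)c1C(=O)c1cn(-c2ccc(C(=O)O)cc2F)c2ncccc12` gives 93%
compound 3 `O=C(O)c1ccc(-n2cc(C(=O)c3c(Cl)cccc3Cl)c3cccnc32)cc1` gives 100%

Compound 3 stands highest of the three numbers: against compound 2 the gap is within the scatter, against compound 1 it is beyond it. Compound 4 `O=C(O)c1ccc(-n2cc(C(=O)c3c(Cl)cccc3Cl)c3cccnc32)c(F)c1` differs from compound 3 by fluoro in place of hydrogen on an aromatic carbon.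

Within the data shown here, the only measured step, a number 6 percentage points higher from compound 1 to compound 2 (within the scatter), concerns a different change and does not bear on this one. Among the measured compounds shown here, no measured step covers fluoro in place of hydrogen. Compound 2 carries the fluoro and gives 93% in this assay, within the scatter of compound 3.

For compound 4 no step beyond the scatter is expected, a number 7 percentage points lower from compound 3 to compound 4 (within the scatter). The estimate for compound 4 in this assay is 93%, between 80% and 100%.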

Compound 4, percent of the compound remaining in the Mus musculus assay: 92%
Compound 4: middle estimate off by 1 percentage points, on the high side; the range from low to high includes it.
By their numbers in the Mus musculus assay, from the lowest: compounds 1, 4, 2 and 3 (each within the scatter of the next, the first and the last beyond it).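

In the Mus musculus assay the step of a number 8 percentage points lower from compound 3 to compound 4 (within the scatter) shows that fluoro on an aromatic carbon ortho to a large group and meta to a carboxy group leaves no readable mark, and with this fluoro in place chloro reads the same as methyl in a number 1 percentage points lower from compound 2 to compound 4 (within the scatter) and as trifluoromethyl in a number 5 percentage points higher from compound 1 to compound 4 (within the scatter) here. In a physicochemical assay for solubility, at pH 4 (a higher number here means a more soluble compound, a lower number a less soluble compound), compound 4 gives < 1000 nM, which is a limit of the assay and not a number: the limit of < 1000 nM in the physicochemical assay, at which 1 of the 2 values shown sits. Among these compounds, in the physicochemical assay compound 3 gives 3000 nM and the step of an at least 3.0-fold lower number from compound 3 to compound 4 (0.47 log units; beyond the scatter) is the one change at this position that reads beyond the scatter.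

Going by these compounds, the actual value of compound 4 in the physicochemical assay stays open. Also open, on these data alone, is how a methoxy group or an amine on this same aromatic carbon would read in the Mus musculus assay and in the physicochemical assay against hydrogen and fluoro.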